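The source may hold more compounds than are shown below. What is called first, only, known or untested is meant among the compounds shown, and "the series" means these compounds.

- compound 1 `COc1ccc2nc(C)cc(NCc3cccc(N(C)C)c3)c2c1` gives 14000 nM
- compound 2 `COc1ccc2nc(C)cc(NCc3cccc(C#N)c3)c2c1` gives 13400 nM

Both values come from a functional assay on MCF-10A cells (Homo sapiens) for antiproliferative activity, with a stated time of 48 h (on this read-out lower numbers stand for an effect already at smaller amounts and higher numbers for an effect only at larger amounts of compound), and lie within the usual scatter of each other, so compound 2 stands level with compound 1. Compound 3 `Cc1cc(NCc2cccc(C#N)c2)c2cc(OCCCN3CCCC3)ccc2n1` differs from compound 2 by 2-(pyrrolidin-1-yl)ethyl in place of hydrogen on a saturated chain carbon bound to an oxygen on an aromatic ring which amounts to methoxy changed to 3-(pyrrolidin-1-yl)propoxy. For the measured compounds named here, the only measured step of a 1.0-fold lower number from compound 1 to compound 2 (0.02 log units; within the scatter) lies elsewhere on the molecule and stayed within the scatter, so it gives little guidance on this change. A lower number is expected, with a 3.4-fold lower number from compound 2 to compound 3 (0.53 log units; beyond the scatter) as the estimated step and few data behind it. In this assay the estimate for compound 3 is 4000 nM with 700 nM to 15000 nM as the expected range.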

Compound 3, half-maximal effective concentration: 8500 nM
Compound 3: middle estimate off by 2.1-fold (0.33 log units), on the low side, and the stated range covers the measured number.
By their numbers in this assay, from the lowest: compounds 3, 2 and 1 (each within the scatter of the next).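

In this assay, replacing methoxy with 3-(pyrrolidin-1-yl)propoxy gives a 1.6-fold lower number from compound 2 to compound 3 (0.20 log units; within the scatter) so compound 2 and compound 3 stand level. The earlier step changed a different place, whereas this one shows that a substantial addition of 7 heavy atoms, including a five-membered ring, on the saturated chain carbon bound to an oxygen on an aromatic ring leaves the read-out within the usual scatter. No supporting measurement is available to explain this result. On these data alone, it remains open whether a shorter chain, or a morpholine ring or carboxylic acid at the chain end, would also leave the number level.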